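Swapping an imidazolylpropyl chain for a dihydroxypropyl-triazole

This account rests on a few compounds, and the source may have more. Where it says the series, first, only, none or still open, it means among the compounds named here.

Compound 1 `O=C1c2c[n+]([O-])c3ccccc3c2C(=O)c2c1c1ccccc1n2CCCCn1ccnc1` is the reference point of this small set. In a functional assay on MDA-MB-231 cells (Homo sapiens) for cytotoxicity, read by MTT assay, with a stated time of 72 h (on this read-out higher numbers stand for weaker inhibition and lower numbers for stronger inhibition), compound 1 gives 210 nM, the lowest number among the three measured compounds. Going by the values given here, compound 2 `CN1CCN(CCCCCCn2c3c(c4ccccc42)C(=O)c2c[n+]([O-])c4ccccc4c2C3=O)CC1` gives 2400 nM, and the only step that differs in one place, an 11-fold higher number from compound 1 to compound 2 (1.06 log units; beyond the scatter), shows how far the number can move when the chain end is exchanged. Among the compounds with values here, compound 3 `O=C1c2c[n+]([O-])c3ccccc3c2C(=O)c2c1c1ccccc1n2Cc1cn([C@@H]2O[C@H](CO)[C@@H](O)[C@H](O)[C@H]2O)nn1`, which carries a triazole bearing a sugar on a methylene at the aromatic nitrogen, gives 650 nM; no single-place step links it to compound 1, so only its value stands as a hint.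

Compound 4 `O=C1c2c[n+]([O-])c3ccccc3c2C(=O)c2c1c1ccccc1n2Cc1cn(C[C@@H](O)CO)nn1` differs from compound 1 by 1-(2,3-dihydroxypropyl)-1H-1,2,3-triazol-4-yl in place of 3-(1H-imidazol-1-yl)propyl on a saturated chain carbon bound to an aromatic nitrogen. Within the data shown here, no measured step bears directly on this change. Because compound 3 650 nM sits above compound 1 and shares the triazolylmethyl motif, a modest weakening is expected, and compound 4 is therefore estimated at 500 nM, in a range of 200 nM to 1500 nM. This estimate corresponds to an expected step of a 2.4-fold higher number from compound 1 to compound 4 (0.38 log units; beyond the scatter).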

Compound 4, half-maximal inhibitory concentration: 670 nM
Compound 4: middle estimate off by 1.3-fold (0.13 log units), on the low side, and the stated range covers the measured number.
By their numbers in this assay, from the lowest: compound 1; then compounds 3 and 4 (each within the scatter of the next); then compound 2.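

In this assay, putting 1-(2,3-dihydroxypropyl)-1H-1,2,3-triazol-4-yl in place of 3-(1H-imidazol-1-yl)propyl gives a 3.2-fold higher number from compound 1 to compound 4 (0.50 log units; beyond the scatter) as a modest step, so this exchange at the saturated chain carbon bound to an aromatic nitrogen weakens inhibition far less than the methylpiperazine chain end did. The group on the triazole's aromatic nitrogen can be 2,3-dihydroxypropyl or the sugar ring: a 1.0-fold higher number from compound 3 to compound 4 (0.01 log units; within the scatter) stays within the scatter, and the two cannot be told apart on this read-out. Against 5-(4-methylpiperazin-1-yl)pentyl, the triazole chain end gives a 3.6-fold lower number from compound 2 to compound 4 (0.55 log units; beyond the scatter) as a modest step beyond the scatter.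

From the compounds shown here alone, whether an amine or a carboxylic acid on the triazole, or a longer chain before it, would move the number stays open. Nothing at hand explains why these steps take the sizes they do.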